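The compounds below may be only part of what the source reports. "The series", "measured", "known", "first", "only" and "open" are said of these compounds alone.

Measured in a physicochemical assay for solubility (on this read-out lower numbers stand for lower solubility and higher numbers for higher solubility), so far:
Compound 1 `O=C(c1ccc(Cl)nc1)N1CCC(NS(=O)(=O)c2cc(S(=O)(=O)c3ccccc3)ccc2C(F)(F)F)CC1` gives 25000 nM
Compound 2 `CC(C)(O)CCN1CCC(NS(=O)(=O)c2cc(S(=O)(=O)c3ccccc3)ccc2C(F)(F)F)CC1` gives 50000 nM

Only these two numbers exist, and compound 2, at 50000 nM on this read-out, lies within the scatter of compound 1. Compound 3 `O=C(C1CCNCC1)N1CCC(NS(=O)(=O)c2cc(S(=O)(=O)c3ccccc3)ccc2C(F)(F)F)CC1` is still unmeasured. It carries (piperidin-4-yl)carbonyl in place of 3-hydroxy-3-methylbutyl on an amine nitrogen in a ring. Within the data shown here, one measured step bears on this change: a 2.0-fold higher number from compound 1 to compound 2 (0.30 log units; within the scatter) with 3-hydroxy-3-methylbutyl replacing (6-chloropyridin-3-yl)carbonyl at that same nitrogen. Among the measured compounds shown here, no measured compound carries the entering group, so this single small step is thin evidence. No step beyond the scatter is expected in this assay in either direction. The estimated step is a 1.1-fold lower number from compound 2 to compound 3 (0.05 log units; within the scatter) and remains an expectation only. For compound 3 the estimated value is 45000 nM and is expected to fall between 18000 nM and 110000 nM.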

Compound 3, solubility: 100000 nM
The estimate for compound 3 lay 2.2-fold (0.35 log units) below the measured number; low and high end bracket the measured number.
By their numbers in this assay, from the lowest: compounds 1, 2 and 3 (each within the scatter of the next, the first and the last beyond it).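

In this assay, among these compounds, the amine nitrogen in a ring now shows a step beyond the scatter: with the carbonyl kept and piperidin-4-yl in place of 6-chloropyridin-3-yl, the result is a 4.0-fold higher number from compound 1 to compound 3 (0.60 log units; beyond the scatter) (the first such step at this position). Replacing 3-hydroxy-3-methylbutyl with (piperidin-4-yl)carbonyl gives a 2.0-fold higher number from compound 2 to compound 3 (0.30 log units; within the scatter), so this read-out does not separate that chain from that acyl group. Nothing at hand explains either step.

On these data alone, it remains open whether the step on the carbonyl goes with the ring nitrogen of piperidin-4-yl or with the loss of the chlorine and the pyridine ring. A cyclohexyl group on the same carbonyl, or a chain ending in a carboxylic acid, would bear on this.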